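The compounds below may be only part of what the source reports. "The series", "measured", "known", "first", "only" and "open" are said of these compounds alone.

In a functional assay on HeLa cells (Homo sapiens) for antiproliferative activity, read by MTT assay, with a stated time of 48 h (on this read-out lower numbers stand for stronger inhibition and higher numbers for weaker inhibition), the series reads as follows:

compound 1 `COC(=O)[C@H](C)NC(=O)c1ccc(Oc2nc3ccccc3nc2C)cc1` gives 32200 nM
compound 2 `Cc1nc2ccccc2nc1Oc1ccc(C(=O)N[C@@H](CC(C)C)C(=O)O)cc1` gives 17300 nM
compound 3 `Cc1nc2cc(Cl)ccc2nc1Oc1ccc(C(=O)N[C@@H](CC(C)C)C(=O)O)cc1` gives 25000 nM

Compound 2 sits within the scatter of both other compounds, so no order can be read among the three. Compound 4 `CC(C)C[C@H](NC(=O)c1ccc(Oc2nc3ccccc3nc2NC(C)(C)C)cc1)C(=O)O` has (tert-butyl)amino in place of methyl on an aromatic carbon of the shared core. Among the compounds with values here, no measured step replaces this methyl, so the data give no direct evidence at this place. The step of a 1.9-fold lower number from compound 1 to compound 2 (0.27 log units; within the scatter) for the change on the amide-type nitrogen lies away from it. Within the data shown here, the only measured change on the core is a 1.4-fold higher number from compound 2 to compound 3 (0.16 log units; within the scatter) for chloro in place of hydrogen on an aromatic carbon, and this small step is the basis for expecting no shift beyond the scatter in this assay here. The expected change is a 1.2-fold lower number from compound 2 to compound 4 (0.06 log units; within the scatter) and no direction is favoured. On these data alone, for compound 4 the estimated value is 15000 nM with an expected range from 5000 nM to 45000 nM kept wide, as the entering group is untested.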

Compound 4, half-maximal inhibitory concentration: 39200 nM
Compound 4: middle estimate off by 2.6-fold (0.42 log units), on the low side; the range from low to high includes it.
By their numbers in this assay, from the lowest: compounds 2, 3, 1 and 4 (each within the scatter of the next, the first and the last beyond it).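

In this assay, (tert-butyl)amino in place of methyl on the aromatic carbon next to the ring nitrogen gives a 2.3-fold higher number from compound 2 to compound 4 (0.36 log units; beyond the scatter), the only step shown that lies beyond the scatter, so this position can shift the read-out towards weaker inhibition, if modestly. The change brings in more heavy atoms, a hydrogen-bond donor and a hydrogen-bond acceptor together, so this single step cannot separate their contributions. No measured property is available to explain the shift.

Still open, on these data alone, is whether a plain amino group, methylamino or an ethyl group at this position would stay within the scatter of compound 2. Also open, as far as these compounds go, is whether the step would carry over to the chloro-bearing core of compound 3 or the 1-(methoxycarbonyl)ethyl amide of compound 1.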